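Anilide series: aryl swap at the amide carbonyl, cytotoxicity

The source may report more compounds than this note shows. Statements on the series, on what has been measured and on what is new or still open speak of the compounds shown alone.

Measured compounds:
compound 1 `Cc1ccc(C(=O)Nc2cc(Cl)ccc2OCC(=O)Nc2ccc(S(N)(=O)=O)cc2C)cc1`: 54200 nM
compound 2 `Cc1cc(S(N)(=O)=O)ccc1NC(=O)COc1ccc(Cl)cc1NC(=O)c1cccc([N+](=O)[O-])c1`: 58800 nM
compound 3 `Cc1ccc(C(=O)Nc2cc(Cl)ccc2OCC(=O)Nc2ccc(S(N)(=O)=O)cc2C)cc1C`: 84100 nM

In a functional assay on C8166 cells (Homo sapiens) for cytotoxicity, read by MTT assay (a lower number here means that less compound is tolerated, a higher number that more compound is tolerated), compound 1 gives 54200 nM, compound 2 gives 58800 nM and compound 3 gives 84100 nM. The three numbers lie close together: the step of a 1.1-fold higher number from compound 1 to compound 2 (0.04 log units; within the scatter) and the step of a 1.6-fold higher number from compound 1 to compound 3 (0.19 log units; within the scatter) are both within the scatter, as is the step of a 1.4-fold higher number from compound 2 to compound 3 (0.16 log units; within the scatter). Among the compounds with values here, compound 3 thus holds the largest number of the three, but its distance to either neighbour is within the scatter, so no compound is separated from another in this assay.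

Compound 4 `Cc1cc(S(N)(=O)=O)ccc1NC(=O)COc1ccc(Cl)cc1NC(=O)c1cccc2ccccc12` is not yet measured. It differs from compound 3 in one place: naphthalen-1-yl in place of 3,4-dimethylphenyl on a carbonyl carbon. The same position has already been varied twice among the measured compounds, from 4-methylphenyl to 3-nitrophenyl and from 3-nitrophenyl to 3,4-dimethylphenyl, and both of those steps stayed within the scatter. Nothing in the measured steps points to a change in tolerated concentration when the aryl group on this carbonyl carbon is exchanged, so for compound 4 the expected step of a 1.3-fold lower number from compound 3 to compound 4 (0.11 log units; within the scatter) is none beyond the scatter. On that basis compound 4 is estimated at 65000 nM in this assay, with a range from 30000 nM to 140000 nM.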

Compound 4, half-maximal cytotoxic concentration: > 381000 nM
Compound 4 gave a limit, no number (the forecaster's own chance of this, stated with the estimate: 10%); at least 5.8-fold (0.76 log units) between middle value and limit.
By their numbers in this assay, from the lowest: compounds 1, 2 and 3 (each within the scatter of the next). At a limit, above all of these: compound 4.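

In this assay the aryl group on this carbonyl carbon proves able to move the read-out, although the three earlier aryl groups stayed within the scatter of one another. The exchange for naphthalen-1-yl gives an at least 4.5-fold higher number from compound 3 to compound 4 (0.65 log units; beyond the scatter), and likewise an at least 6.4-fold higher number from compound 2 to compound 4 (0.81 log units; beyond the scatter) and an at least 7.0-fold higher number from compound 1 to compound 4 (0.84 log units; beyond the scatter). The reading for compound 4 is a limit and not a number: the limit of > 381000 nM in this assay, at which 1 of the 4 values shown sits.

Compound 4 is the only one shown with 2 six-membered aromatic rings of carbon only, so the second ring and the naphthalen-1-yl arrangement as such cannot be told apart, and the full size of all three steps stays unknown. Also open, on these data alone, is whether naphthalen-2-yl, a saturated cyclohexyl group or a phenyl ring carrying an amine or a carboxylic acid on the same carbonyl carbon would stay with compounds 1, 2 and 3 or go with compound 4.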